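A few compounds are considered here, and "the series" means these few. Any claim that something is new, unique, unknown or untested is made for them only; others in the source may bear on it.

Measured compounds:
- compound 1 `Cc1ccc(NC(=O)Nc2cc(/C(=N/O)Nc3ccc(F)c(Br)c3)ccc2N(CC(C)C)CC(C)C)cc1`: 2300 nM in an assay on isolated protein for inhibition of Indoleamine 2,3-dioxygenase 1 (Homo sapiens); on this read-out lower numbers stand for stronger inhibition and higher numbers for weaker inhibition
- compound 2 `CC(C)CN(CC(C)C)c1ccc(/C(=N/O)Nc2ccc(F)c(Br)c2)cc1NC(=O)Nc1ccc(Cl)cc1`: 1490 nM in this assay
- compound 3 `Cc1ccc(NC(=O)Nc2cc(/C(=N/O)Nc3ccc(C)cc3)ccc2N(CC(C)C)CC(C)C)cc1`: 1560 nM in this assay

Compound 2 gives the lowest of the three numbers, yet all three sit within the scatter of one another: the step of a 1.5-fold lower number from compound 1 to compound 2 (0.19 log units; within the scatter) and the step of a 1.5-fold lower number from compound 1 to compound 3 (0.17 log units; within the scatter) are both small. Compound 4 `CC(C)CN(CC(C)C)c1ccc(/C(=N/O)Nc2ccc(F)c(Br)c2)cc1NC(=O)Nc1ccc(C(F)(F)F)cc1` differs from compound 2 in one place, (trifluoromethyl in place of chloro on an aromatic carbon). For the measured compounds named here, the only measured step at that same aromatic carbon, a 1.5-fold lower number from compound 1 to compound 2 (0.19 log units; within the scatter), stayed within the scatter, and no measured pair shows a trifluoromethyl group. Compound 4 is therefore expected to stay close to compound 2, with a step of a 1.1-fold lower number from compound 2 to compound 4 (0.03 log units; within the scatter) that does not exceed the scatter. The estimate for compound 4 in this assay is 1400 nM, within a range from 700 nM to 2800 nM.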

Compound 4, half-maximal inhibitory concentration: > 3000 nM
Compound 4 ended at the assay's limit (the forecaster's own chance of this, stated with the estimate: 5%); middle value at least 2.1-fold (0.33 log units) from the limit.
By their numbers in this assay, from the lowest: compounds 2, 3 and 1 (each within the scatter of the next). At a limit, above all of these: compound 4.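

Compound 4 gives a limit in this assay, not a number: the limit of > 3000 nM in this assay, at which 1 of the 4 values shown sits. At this aromatic carbon, trifluoromethyl gives an at least 2.0-fold higher number from compound 2 to compound 4 (0.30 log units; that floor lies within the scatter) with chloro as the starting group and an at least 1.3-fold higher number from compound 1 to compound 4 (0.11 log units; that floor lies within the scatter) with methyl as the starting group. Both are floors, so the true steps may be larger, and a position that looked flat across methyl and chloro may not stay flat for trifluoromethyl, although neither floor passes the scatter.

On these data alone, how far compound 4 lies past its limit stays open. As far as these compounds go, it also remains open whether a fluoro, a methoxy or an amine at this carbon would stay close to compound 2.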